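The source may report more compounds than this note shows. Statements on the series, on what has been measured and on what is new or still open speak of the compounds shown alone.

Compound 1, `Cc1ccc(-c2nc3c(c(-c4ccccc4)nn3-c3ccccc3)c(-c3ccc(O)cc3)c2C#N)cc1`: in a functional assay on MV4-11 cells (Homo sapiens) for antiproliferative activity, read by resazurin assay, with a stated time of 72 h (a lower number here means a stronger inhibitor, a higher number a weaker inhibitor), compound 1 gives 3300 nM.
Compound 2, `N#Cc1c(-c2cccs2)nc2c(c(-c3ccccc3)nn2-c2ccccc2)c1-c1ccc(O)cc1`: in this assay compound 2 gives 34200 nM.
Compound 3, `COc1cc(-c2c(C#N)c(-c3ccccc3)nc3c2c(-c2ccccc2)nn3-c2ccccc2)ccc1O`: in this assay compound 3 reaches only a limit of the assay, > 50000 nM, and not a number; this is the limit (the limit of > 50000 nM in this assay, at which 1 of the 3 values shown sits).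

Among the numbers shown, compound 2 has the highest, and its nearest neighbour is compound 1, which sits a long way beneath it. Among the compounds with values here, the one measured step that connects them, a 10-fold higher number from compound 1 to compound 2 (1.02 log units; beyond the scatter), shows how much the swap of a six-membered carbon ring for a five-membered sulfur-containing ring raised the number.

Compound 4, `N#Cc1c(-c2ccc(F)cc2)nc2c(c(-c3ccccc3)nn2-c2ccccc2)c1-c1ccc(O)cc1`, is not yet measured. It differs from compound 2 at one place: 4-fluorophenyl in place of thiophen-2-yl on an aromatic carbon. This change restores a six-membered carbon-only ring at the position where the thiophen-2-yl ring had pushed the number up. From the compounds shown here alone, that measured step is the only one bearing on the new one, and it was large, so a drop of comparable size in this assay is expected, back toward the region of compound 1, though the fluorine is untested here and widens the uncertainty. The step expected is a 7.6-fold lower number from compound 2 to compound 4 (0.88 log units; beyond the scatter). Compound 4 is therefore estimated at 4500 nM, within a range from 1200 nM to 18000 nM.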

Compound 4, half-maximal inhibitory concentration: 11600 nM
Compound 4: middle estimate off by 2.6-fold (0.41 log units), on the low side, within the range that was stated.
By their numbers in this assay, from the lowest: compound 1; then compound 4; then compound 2. At a limit, above all of these: compound 3.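

In this assay a six-membered carbon ring at this position, next to the ring nitrogen, brings back only part of what thiophen-2-yl lost: the change gives a 2.9-fold lower number from compound 2 to compound 4 (0.47 log units; beyond the scatter) and so does not return to the level of compound 1. What that ring carries also counts, since fluoro in place of methyl gives a 3.5-fold higher number from compound 1 to compound 4 (0.55 log units; beyond the scatter) with the rest of the molecule unchanged. Among these three groups, 4-methylphenyl gives the lowest number, 4-fluorophenyl the middle one and thiophen-2-yl the highest, and every gap between them lies beyond the scatter.

Nothing shown here explains why these changes move the number. From the compounds shown here alone, it also remains open whether a chlorine, a methoxy group or an amine on that six-membered ring would match or improve on methyl.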